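A few compounds are considered here, and "the series" means these few. Any claim that something is new, unique, unknown or untested is made for them only; others in the source may bear on it.

Among the compounds with values here, in a functional assay on A549 cells (Homo sapiens) for inhibition, read by MTT assay, with a stated time of 48 h (a higher number here means a weaker inhibitor, a lower number a stronger inhibitor), compound 1 (`COc1cc(-c2nccn3cc(-c4ccc(Cl)cc4)nc23)cc(OC)c1OC`) gives 7290 nM, the only actual number so far. Compound 2 (`COc1cc(-c2nccn3cc(-c4ccc([N+](=O)[O-])cc4)nc23)cc(OC)c1OC`) reads > 10000 nM, which is a limit. Compound 3 (`COc1cc(-c2nccn3cc(-c4ccc(C(F)(F)F)cc4)nc23)cc(OC)c1OC`) reads > 10000 nM, again a limit. Compound 1 therefore stands not far short of the limit of > 10000 nM in this assay, at which 2 of the 3 values shown sit.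

Compound 4 (`COc1cc(-c2nccn3cc(-c4ccc(C)cc4)nc23)cc(OC)c1OC`) has methyl in place of chloro on an aromatic carbon, para to a large group: methyl in place of chloro on an aromatic carbon. The steps bearing on this change are an at least 1.3-fold higher number from compound 1 to compound 2 (0.13 log units; that floor lies within the scatter) and an at least 1.3-fold higher number from compound 1 to compound 3 (0.13 log units; that floor lies within the scatter). Both are floors only, and both replace the same chloro. No step beyond the scatter is therefore expected in this assay, though a reading at the limit remains possible. The estimated step is a 1.1-fold higher number from compound 1 to compound 4 (0.04 log units; within the scatter). Compound 4 is expected at 8000 nM, with an estimated range of 3500 nM to 10000 nM.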

Compound 4, half-maximal inhibitory concentration: 135 nM
Beside the measured number, compound 4's estimate is 59-fold (1.77 log units) above it; measured number outside the range, below it.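

In this assay, within the data shown here, this position proves far more sensitive than the earlier compounds could show, since exchanging one heavy atom gives a 54-fold lower number from compound 1 to compound 4 (1.73 log units; beyond the scatter). Against the other two groups the steps are an at least 74-fold lower number from compound 3 to compound 4 (1.86 log units; beyond the scatter) and an at least 74-fold lower number from compound 2 to compound 4 (1.86 log units; beyond the scatter), both floors resting on limits, which makes compound 4 the strongest inhibitor shown. Only 4-methylphenyl stands clear of that ceiling: the limit of > 10000 nM in this assay, at which 2 of the 4 values shown sit.

As far as these compounds go, whether the gain is particular to methyl remains open. A longer chain such as ethyl, or a methoxy or an amine in the same place, would test this.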